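Swapping a halogenated aryl ester for a methyl analogue

The source may report more compounds than this note shows. Statements on the series, on what has been measured and on what is new or still open speak of the compounds shown alone.

Of the compounds shown here, three sharing one core have been tested in an ADME assay on cells (T-cell, Mus musculus, strain BALB/c) for cytotoxicity, read by MTT assay, with a stated time of 48 h; a lower number here means that less compound is tolerated, a higher number that more compound is tolerated. Compound 1 `COC(=O)c1c(F)cccc1OC(=O)COc1cc(O)c2c(=O)cc(-c3ccccc3)oc2c1` gives 319000 nM in this assay. Compound 2 `COC(=O)c1c(Br)cc(Br)cc1OC(=O)COc1cc(O)c2c(=O)cc(-c3ccccc3)oc2c1` gives 398000 nM in this assay, and compound 3 `COC(=O)c1c(Cl)cc(Cl)cc1OC(=O)COc1cc(O)c2c(=O)cc(-c3ccccc3)oc2c1` gives 345000 nM in this assay. Compound 1 has the lowest of the three numbers, but the gaps to compound 3 and to compound 2 both lie within the usual scatter of repeated measurements, so the three cannot be told apart on these data.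

The fourth compound, compound 4 `COC(=O)c1ccc(C)cc1OC(=O)COc1cc(O)c2c(=O)cc(-c3ccccc3)oc2c1`, has not yet been measured in this assay. It differs from compound 1 in one place: a group of 11 heavy atoms (9 carbon, 2 oxygen; one six-membered aromatic ring of carbon only) in place of a group of 11 heavy atoms (8 carbon, 2 oxygen, 1 fluorine; one six-membered aromatic ring of carbon only), on an oxygen next to a carbonyl group. The rest of the molecule is unchanged.

For the measured compounds named here, no pair of measured compounds that differ in one place is available to guide this step, so the expectation rests only on the three values shown. Since the halogen variants of compound 1, compound 2 and compound 3 all fall inside the scatter of one another, no step beyond the scatter is expected in this assay for this change. Compound 4 is therefore estimated to give 330000 nM in this assay, with a range from 200000 nM to 550000 nM. The expected step of a 1.0-fold higher number from compound 1 to compound 4 (0.01 log units; within the scatter) amounts to no change beyond the scatter.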

Compound 4, half-maximal cytotoxic concentration: 250000 nM
Compound 4: the middle estimate sits 1.3-fold (0.12 log units) above what was measured; the range from low to high includes it.
By their numbers in this assay, from the lowest: compounds 4, 1, 3 and 2 (each within the scatter of the next).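

In this assay, putting the new methyl-bearing aromatic group in place of the 3-fluoro-2-(methoxycarbonyl)phenyl group, on an oxygen next to a carbonyl group, gives a 1.3-fold lower number from compound 1 to compound 4 (0.11 log units; within the scatter) and so no change that can be told from the usual scatter. For the compounds shown here, this is the first comparison here of two compounds that differ in just one place, and it gives a direct reading that the earlier compounds could not provide, since all of them carry halogen atoms on this aromatic ring. In this single pair, a group with no halogen at all is tolerated much like the fluorine-bearing group it replaces, although no measured property of either group is available to explain the result.

The groups shown at this position are all aromatic carbon rings that carry a methoxycarbonyl group, so it remains open whether an amine or a carboxylic acid on that ring would move the number beyond the scatter. Going by these compounds, it is also open whether a simple alkyl chain in place of the whole aromatic group would do so.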